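This account rests on a few compounds, and the source may have more. Where it says the series, first, only, none or still open, it means among the compounds named here.

Measured so far:

Compound 1, `Nc1nc(Cl)c2ncn(Cc3ccc(CCl)cc3)c2n1`: 97700 nM
Compound 2, `ClCc1cccc(Cn2cnc3c(Cl)nc(Cl)nc32)c1`: 8910 nM
Compound 3, `ClCc1ccc(Cn2cnc3c(Cl)nc(Cl)nc32)cc1`: 44700 nM

The three compounds were tested in a functional assay on TK-10 cells (Homo sapiens) for cytotoxicity, read by sulforhodamine B assay, with a stated time of 48 h; a higher number here means that more compound is tolerated, a lower number that less compound is tolerated. Compound 2 gives the lowest of the three numbers, 8910 nM, in this assay. Compound 3 stands next to it with 44700 nM, and compound 1 gives 97700 nM. Compounds 2 and 3 are built from the same atoms joined differently; the difference between their two cores is not broken down here.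

Compounds 3 and 1 differ in one place: amino in place of chloro on an aromatic carbon. This change gave a 2.2-fold higher number from compound 3 to compound 1 (0.34 log units; beyond the scatter), a modest step that nonetheless lies beyond the usual scatter of the assay.

Compound 4, `Nc1nc(Cl)c2ncn(Cc3cccc(CCl)c3)c2n1`, has not yet been measured in this assay. It is related to compound 2 by the same change, (amino in place of chloro on an aromatic carbon), made on the same kind of position of the shared core. Since the place of the change is described in identical terms for both pairs, the step seen from compound 3 to compound 1 is the natural guide for what to expect here. Compound 4 is therefore expected to give a higher number than compound 2, with a step of about a 2.1-fold higher number from compound 2 to compound 4 (0.33 log units; beyond the scatter), because the same change produced a 2.2-fold higher number from compound 3 to compound 1 (0.34 log units; beyond the scatter). On this basis compound 4 is estimated at 19000 nM, with a plausible range from 9000 nM to 45000 nM.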

Compound 4, concentration lethal to 50% of the cells: 27500 nM
Estimate against measurement, compound 4: 1.4-fold (0.16 log units) below; the range from low to high includes it.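

In this assay, amino in place of chloro on an aromatic carbon gave a 3.1-fold higher number from compound 2 to compound 4 (0.49 log units; beyond the scatter), a step in the same direction as the one seen earlier on the other core. The two steps cannot be told apart in size: the same change on two cores in this assay, a 2.2-fold higher number (0.34 log units; beyond the scatter) from compound 3 to compound 1 and a 3.1-fold higher number (0.49 log units; beyond the scatter) from compound 2 to compound 4, 1.4-fold (0.15 log units) apart, within the scatter of two such steps. Among the compounds shown here, this shows that the change carried over between these two cores, which are built from the same atoms joined differently, with a similar result, but it rests on only two pairs in a single cell line and shows neither that it would carry over to any other core nor why the number rises.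

The compounds shown leave open whether a different group in the same place, such as a methylamine, a methoxy group or a hydroxyl, would give a step of similar direction and size to that of the amino group. They also leave open how the numbers would respond if the chloro group that remains on the six-membered ring were replaced by an amine, or if the chloromethyl group were replaced by a hydroxymethyl group or a longer chain.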